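The source may report more compounds than this note shows. Statements on the series, on what has been measured and on what is new or still open speak of the compounds shown alone.

Measured compounds:
Compound 1, `COc1cc(C(=O)O)ccc1OCCCCOc1ccc(C(=O)CC(C)C)c(O)c1C`; in an assay on HEK293 cells for positive allosteric modulation of metabotropic glutamate receptor 3 (Rattus norvegicus), read by thallium flux, with a stated time of 2.5 min (a higher number here means a larger maximal response, a lower number a smaller maximal response), compound 1 gives 73.9%.
Compound 2, `Cc1c(OCCCCOc2ccc(C(=O)O)cc2)ccc(C(=O)CC(C)C)c1O`; compound 2 gives 51.9%.
Compound 3, `Cc1c(OCCCCOc2cccc(C(=O)O)c2)ccc(C(=O)CC(C)C)c1O`; compound 3 gives 69.9%.

Compound 4, `COc1ccc(C(=O)O)cc1OCCCCOc1ccc(C(=O)CC(C)C)c(O)c1C`, has not yet been measured. It differs from compound 3 by methoxy in place of hydrogen on an aromatic carbon. The same kind of change has been made once before: compound 1 differs from compound 2 by methoxy in place of hydrogen on an aromatic carbon, and that step was a number 22 percentage points higher from compound 2 to compound 1 (beyond the scatter). The two cores themselves differ by 3-carboxyphenyl in place of 4-carboxyphenyl on an oxygen on a saturated carbon, a step of a number 18 percentage points higher from compound 2 to compound 3 (beyond the scatter). The place is not identical, though: in the earlier change the entering methoxy is meta to the carboxy group, here it is para to it, so this is the same kind of change, not the same change. For compound 4 a step of a number 10.1 percentage points higher from compound 3 to compound 4 (beyond the scatter) is expected, somewhat smaller than the earlier one because compound 3 already gives 69.9%. Compound 4 is therefore estimated at 80%, likely between 62% and 98%.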

Compound 4, largest response reached (reported as percent of maximum), in percent of the reference or control that the assay uses: 100%
Estimate against measurement, compound 4: 20 percentage points below; the measured number lies above the stated range.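

Methoxy in place of hydrogen on an aromatic carbon raises the maximal response in this assay on both cores, and the new step is a number 30.1 percentage points higher from compound 3 to compound 4 (beyond the scatter). The two steps agree as closely as this kind of measurement can tell: the same change on two cores in this assay, a number 22 percentage points higher (beyond the scatter) from compound 2 to compound 1 and a number 30.1 percentage points higher (beyond the scatter) from compound 3 to compound 4, 8.1 percentage points apart, within the scatter of two such steps. So the gain carries over between these two cores, but two pairs cannot show that it would hold on any other core, nor that the two methoxy places, one of them para to a carboxy group, are equivalent.

Going by these compounds, whether an ethoxy or a chlorine in the same place would give a similar step remains open. So does whether the step would survive a shorter or longer chain between the two aromatic rings.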